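This account rests on a few compounds, and the source may have more. Where it says the series, first, only, none or still open, it means among the compounds named here.

Measured compounds:
Compound 1, `O=C1/C(=C/c2ccccc2)CCC/C1=C\c1ccc(O)cc1`: 42300 nM
Compound 3, `O=C1/C(=C/c2ccccc2)CCC/C1=C\c1cccc(O)c1`: 28400 nM
Compound 2, `O=C(/C=C(O)/C=C/c1ccc(O)cc1)c1cc(Cl)ccc1O`: "not determined" (no result reported)

In an assay on isolated protein for inhibition of Alpha glucosidase (Homo sapiens), with stated times of 5 min and 15 min (on this read-out lower numbers stand for stronger inhibition and higher numbers for weaker inhibition), compound 1 gives 42300 nM and compound 3 gives 28400 nM. Within the data shown here, the two share a core and differ by 3-hydroxyphenyl in place of 4-hydroxyphenyl on a double-bonded chain carbon bound to a double-bonded ring carbon; the step of a 1.5-fold lower number from compound 1 to compound 3 (0.17 log units; within the scatter) is the only measured instance of this change, and it does not move the read-out beyond the scatter.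

Compound 2 was also tested in this assay, but no number was reported for it. Compound 4, `O=C(/C=C(O)/C=C/c1cccc(O)c1)c1cc(Cl)ccc1O`, is not yet measured. It is related to compound 2 by 3-hydroxyphenyl in place of 4-hydroxyphenyl on a double-bonded chain carbon bound to a double-bonded chain carbon. The difference between the core of compound 2 and the core of compound 1 is not broken down here. The place of the change is not the same in the two pairs: in compound 1 the double-bonded chain carbon is bound to a double-bonded ring carbon, whereas in compound 2 it is bound to a double-bonded chain carbon, so the change from compound 2 to compound 4 is the same kind of change rather than the same change.

Because a 1.5-fold lower number from compound 1 to compound 3 (0.17 log units; within the scatter) stays within the scatter, the author expects the same kind of change on the core of compound 2 to make only a small step in this assay as well. Since compound 2 gave no number, there is no anchor for compound 4 on its own core, and the expectation rests on compound 1 and compound 3 alone. In this assay compound 4 is estimated at 30000 nM, with a wide range from 8000 nM to 120000 nM.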

Compound 4, half-maximal inhibitory concentration: 36400 nM
Compound 4: the middle estimate sits 1.2-fold (0.08 log units) below what was measured, and the stated range covers the measured number.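

Among these compounds, compound 2 has no number in this assay, so the result for compound 4 at 36400 nM gives no step that can be read between the two. Nothing shown here bears on this result. The compounds shown leave open whether 3-hydroxyphenyl in place of 4-hydroxyphenyl, on a double-bonded chain carbon bound to a double-bonded chain carbon, moves the read-out on the core of compound 2.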